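Chloro for fluoro on a methylsulfonyl-bearing core

A few compounds are considered here, and "the series" means these few. Any claim that something is new, unique, unknown or untested is made for them only; others in the source may bear on it.

Compound 1 `CS(=O)(=O)c1cc(F)ccc1NCC1=NCCN1`: 61%
Compound 2 `CSc1ccc(F)cc1NCC1=NCCN1`: 90%
Compound 3 `CSc1ccc(Cl)cc1NCC1=NCCN1`: 82%

Of the compounds shown here, three have been measured in a functional assay for agonist activity at Alpha-1A adrenergic receptor (Homo sapiens); a lower number here means a smaller maximal response, a higher number a larger maximal response. Compound 2 gives 90%, and compound 3 gives 82%; the change between them is chloro in place of fluoro on an aromatic carbon, and it made a step of a number 8 percentage points lower from compound 2 to compound 3 (within the scatter). Compound 1 gives 61% in this assay, the lowest of the three numbers, and the difference between its core and that of compound 2 is not broken down here.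

Compound 4 `CS(=O)(=O)c1cc(Cl)ccc1NCC1=NCCN1` has not yet been measured in this assay. It differs from compound 1 by chloro in place of fluoro on an aromatic carbon. This is the same kind of change as that from compound 2 to compound 3, though the surroundings differ: here the place is meta to a methylsulfonyl group and para to a group of 7 heavy atoms, whereas there it was meta to a group of 7 heavy atoms and para to a methylsulfanyl group. Resting on compound 1 at 61% and on the step of a number 8 percentage points lower from compound 2 to compound 3 (within the scatter), a step of a number 5 percentage points lower from compound 1 to compound 4 (within the scatter) is expected. Compound 4 is therefore estimated at 56%, between 40% and 72%.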

Compound 4, largest response reached (reported as maximum), in percent of the reference or control that the assay uses: 41%
For compound 4 the middle estimate is 15 percentage points above the measured one; the range from low to high includes it.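

In this assay, chloro in place of fluoro on the core of compound 1 gave a step of a number 20 percentage points lower from compound 1 to compound 4 (beyond the scatter), so on this core the change lowered the maximal response by more than the usual scatter. Set beside the same change on the core of compound 2, the steps point the same way and do not differ by more than the scatter of two such steps: the same change on two cores in this assay, a number 8 percentage points lower (within the scatter) from compound 2 to compound 3 and a number 20 percentage points lower (beyond the scatter) from compound 1 to compound 4, 12 percentage points apart, within the scatter of two such steps. Among these compounds, this is consistent with the change carrying across the two cores, but it does not show that the step has the same size on both, as each core offers only one pair.

The compounds shown leave open how a bromo or methoxy group on that aromatic carbon would compare with fluoro and chloro on either core. They also leave open how the methylsulfonyl and methylsulfanyl groups compare when all else is held the same.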